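The compounds below may be only part of what the source reports. "The series", "measured", "known", "first", "only" and "open" are said of these compounds alone.

Compound 1 `Cc1ccccc1-c1nn(-c2ccc(F)cc2F)cc1CNCCN(C)C`: > 20000 nM
Compound 2 `Cc1ccc(-c2nn(-c3ccc(F)cc3F)cc2CNCCN2CCN(C)CC2)cc1`: > 20000 nM

In an ADME assay on Huh-7 cells (Homo sapiens) for cytotoxicity (a higher number here means that more compound is tolerated, a lower number that less compound is tolerated), compound 1 gives > 20000 nM, a limit of the assay rather than a number. In this assay compound 2 gives > 20000 nM, likewise a limit. Going by the values given here, compound 1 thus stands at the limit of > 20000 nM in this assay, at which 2 of the 2 values shown sit, and no step between measured compounds can be read. Compound 3 `CCCN1CCC(CNCc2cn(-c3ccc(F)cc3F)nc2-c2ccccc2C)CC1` awaits testing in this assay; it differs from compound 1 by 1-propylpiperidin-4-yl in place of (dimethylamino)methyl on a saturated chain carbon bound to an amine nitrogen. Nothing shown points either way, so the step from compound 1 to compound 3 is expected to be a step that the limit leaves unreadable from compound 1 to compound 3, none beyond the scatter. Compound 3 is expected to give 25000 nM in this assay, between 10000 nM and 60000 nM.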

Compound 3, half-maximal cytotoxic concentration: > 20000 nM
Compound 3: only a limit was reported; the forecaster's own chance of this, stated with the estimate: 75%; the middle value lies beyond the limit too.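

No new step can be read between compound 1 and compound 3, because both values are limits: the limit of > 20000 nM in this assay, at which 3 of the 3 values shown sit. The compounds shown leave open whether any of them differs from another in this assay at all.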